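Cytotoxicity of the series: one ring stereocentre inverted

This account rests on a few compounds, and the source may have more. Where it says the series, first, only, none or still open, it means among the compounds named here.

- compound 1 `Nc1nc2c(ncn2/C=C2/C[C@@H]2[C@@H](O)CO)c(=O)[nH]1`: 56000 nM
- compound 2 `Nc1nc2c(ncn2/C=C2/CC2(CO)CO)c(=O)[nH]1`: 46000 nM
- compound 3 `Nc1ncnc2c1ncn2/C=C1\C[C@@H]1[C@@H](O)CO`: 50600 nM

In an ADME assay on Akata cells (Homo sapiens) for cytotoxicity (on this read-out lower numbers stand for higher toxicity in this test and higher numbers for lower toxicity in this test), compound 1 stands within the usual scatter of both other measured compounds, so these three values show no order. Compound 4 `Nc1nc2c(ncn2/C=C2/C[C@H]2[C@@H](O)CO)c(=O)[nH]1` is next in this assay. It has the same atoms and bonds as compound 1 and differs only in configuration as drawn (the two compounds have the same atoms and bonds and differ only in configuration as drawn: 1 of 3 stereo elements differ; a stereocentre at a saturated ring carbon is drawn S in compound 1 and R in compound 4): a stereocentre at a saturated ring carbon is drawn S in compound 1 and R in compound 4.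

Within the data shown here, no measured pair shows the effect of this change directly. Among the measured compounds shown here, the only guide is that compound 2 at 46000 nM and compound 3 at 50600 nM both lie within the scatter of compound 1 at 56000 nM, although their structures differ. No step beyond the scatter is therefore expected, in either direction. The expected change is small: a 1.1-fold lower number from compound 1 to compound 4 (0.05 log units; within the scatter). For compound 4 the estimated value is 50000 nM, with an expected range of 25000 nM to 100000 nM.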

Compound 4, half-maximal cytotoxic concentration: 78000 nM
Estimate against measurement, compound 4: 1.6-fold (0.19 log units) below; measured number inside the range.
By their numbers in this assay, from the lowest: compounds 2, 3, 1 and 4 (each within the scatter of the next).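

In this assay, inverting the stereocentre at the saturated ring carbon from S to R gives a 1.4-fold higher number from compound 1 to compound 4 (0.14 log units; within the scatter). Among these compounds, this pair is the first direct reading of that stereocentre, with no other structural change to separate out: the fact that compounds 1 and 4 differ only in the configuration as drawn. Among the compounds shown here, for this pair, the S or R drawing at this ring carbon therefore makes no difference beyond the scatter, a result that the earlier compounds, which differ from one another in more than one place, could not give.

Going by these compounds, whether the same inversion stays within the scatter on the core of compound 3, or when either of the other two stereo elements is changed, remains open. Also open, on these data alone, is whether an amine or a carboxylic acid in place of a hydroxyl group would shift the number beyond the scatter.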